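Moving the Hydroxyl Group Lowers Topoisomerase Inhibition

The source may report more compounds than this note shows. Statements on the series, on what has been measured and on what is new or still open speak of the compounds shown alone.

Measured so far:
compound 1, `Oc1cccc(-c2cc(-c3cccs3)cc(-c3ccccc3O)n2)c1`: 83.2%
compound 2, `Oc1ccc(-c2cc(-c3cccs3)cc(-c3ccccc3O)n2)cc1`: 72.2%
compound 3, `Oc1cccc(-c2cc(-c3ccco3)cc(-c3ccccc3O)n2)c1`: 90.1%

These three compounds were tested in an assay on isolated protein for inhibition of DNA topoisomerase 1 (Homo sapiens), with a stated time of 30 min, tested at 100 uM; on this read-out higher numbers stand for a stronger effect at the one concentration tested and lower numbers for a weaker effect. From compound 1 to compound 3 the change is furan-2-yl in place of thiophen-2-yl on an aromatic carbon, and the step is a number 6.9 percentage points higher from compound 1 to compound 3 (within the scatter), so the two values show no real difference. From compound 1 to compound 2 the change is 4-hydroxyphenyl in place of 3-hydroxyphenyl on an aromatic carbon, and the step is a number 11 percentage points lower from compound 1 to compound 2 (beyond the scatter), a drop.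

Compound 4, `Oc1ccc(-c2cc(-c3ccco3)cc(-c3ccccc3O)n2)cc1`, has not yet been measured. It differs from compound 3 by 4-hydroxyphenyl in place of 3-hydroxyphenyl on an aromatic carbon. This is the same kind of change as that from compound 1 to compound 2, though not the same, since the hydroxyphenyl group is meta to a furan-2-yl group here, where it was meta to a thiophen-2-yl group before. The two cores differ as told by furan-2-yl in place of thiophen-2-yl on an aromatic carbon.

Because compound 1 to compound 2 gave a number 11 percentage points lower from compound 1 to compound 2 (beyond the scatter), a step of similar size, a number 11.1 percentage points lower from compound 3 to compound 4 (beyond the scatter), is expected from compound 3 to compound 4. Compound 4 is therefore estimated to give 79%, expected to lie between 68% and 90%.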

Compound 4, a percentage reported as inhibition, at one concentration (the size of the read-out at that concentration, not a potency): 83%
Estimate against measurement, compound 4: 4 percentage points below; measured number inside the range.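

In this assay, 4-hydroxyphenyl in place of 3-hydroxyphenyl gives a number 7.1 percentage points lower from compound 3 to compound 4 (within the scatter), and this step agrees with the one seen on the thiophen-2-yl core: the same change on two cores in this assay, a number 11 percentage points lower (beyond the scatter) from compound 1 to compound 2 and a number 7.1 percentage points lower (within the scatter) from compound 3 to compound 4, 3.9 percentage points apart, within the scatter of two such steps. Furan-2-yl in place of thiophen-2-yl gives a number 10.8 percentage points higher from compound 2 to compound 4 (beyond the scatter), and this step also agrees with its earlier counterpart: the same change on two cores in this assay, a number 6.9 percentage points higher (within the scatter) from compound 1 to compound 3 and a number 10.8 percentage points higher (beyond the scatter) from compound 2 to compound 4, 3.9 percentage points apart, within the scatter of two such steps. Each change therefore carries over between these two cores within what the assay can resolve, but this does not establish a firm effect on every core, as each pair holds one step within the scatter and one beyond it, and a reading at one concentration is not a potency.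

The compounds shown leave open whether the pattern extends past these four compounds, for example if an amine or a methoxy group took the place of the hydroxyl group on the 3-hydroxyphenyl or 4-hydroxyphenyl ring. They also leave open what would happen if a longer chain stood where the furan-2-yl or thiophen-2-yl group sits.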